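Swapping one small amine for another on a shared core

This account rests on a few compounds, and the source may have more. Where it says the series, first, only, none or still open, it means among the compounds named here.

Three analogues of one shared core have been tested in a functional assay on EL4 cells (Mus musculus) for inhibition, tested at 100 uM; a lower number here means less inhibition, a higher number more inhibition at the concentration tested (going by the name of the read-out). Compound 1 `CSc1[nH]ccc2ncnc1-2` gives only a limit of the assay, < 5%. Compound 2 `c1ccc(Nc2[nH]ccc3ncnc2-3)cc1` gives 26%. Compound 3 `CN(C)c1[nH]ccc2ncnc1-2` gives 25%, which stands beside compound 2 within the usual scatter. For the measured compounds named here, the single measured step, a number at least 20 percentage points higher from compound 1 to compound 3 (beyond the scatter), rests on the limit of < 5% in this assay, at which 1 of the 3 values shown sits, at its start and runs from a limit to a number. Compound 4 `CCNc1[nH]ccc2ncnc1-2` differs from compound 3 as ethylamino in place of dimethylamino on an aromatic carbon. Going by the values given here, no measured step exchanges one amine for another amine, so compound 3 alone guides the expectation, and no step beyond the scatter is expected, no change at the digits printed from compound 3 to compound 4 (within the scatter). Compound 4 is therefore estimated at 25%, between 10% and 40%.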

Compound 4, a percentage reported as inhibition, at one concentration (the size of the read-out at that concentration, not a potency): < 5%
Compound 4: only a limit was reported; the forecaster's own chance of this, stated with the estimate: 10%; middle value at least 20 percentage points from the limit.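

Exchanging dimethylamino for ethylamino in this assay gives a number at least 20 percentage points lower from compound 3 to compound 4 (beyond the scatter), so at this position two amines built from the same atoms are not interchangeable. A hydrogen on the amine nitrogen does not settle the matter alone, since compound 2 also carries one and gives 26%. Compound 4 gives only a limit, so the true drop may be larger, and the step between the two limit compounds cannot be read: the limit of < 5% in this assay, at which 2 of the 4 values shown sit.

As far as these compounds go, whether methylamino, a longer chain such as propylamino, or a ring amine such as pyrrolidine follows compound 3 or compound 4 remains open.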